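The source may report more compounds than this note shows. Statements on the series, on what has been measured and on what is new or still open speak of the compounds shown alone.

Working notes on the series, read in a functional assay on HCT-8 cells (Homo sapiens) for antiproliferative activity, read by MTT assay, with a stated time of 48 h; a lower number here means a stronger inhibitor, a higher number a weaker inhibitor. Compound 1 (`COc1ccc(C(=O)c2ccc(OC)c3c2OC(C)(C)C=C3)c(NC(=O)CO)c1`) gives 230 nM and compound 2 (`C=C(c1cc(OC)c(OC)c(OC)c1)c1ccc(OC)c(O)c1NC(C)=O`) gives 340 nM. Among the compounds with values here, these two values lie within the usual scatter of each other, so compound 2 stands level with the only other measured member and no order can be drawn between them.

Compound 3 (`C=C(c1cc(OC)c(OC)c(OC)c1)c1ccc(OC)c(O)c1NC(=O)CN(C)C`) departs from compound 2 at one place: dimethylamino in place of hydrogen on a saturated chain carbon bound to a carbonyl carbon. In words, dimethylamino stands in place of hydrogen on a saturated chain carbon bound to a carbonyl carbon, which turns acetamido into (((dimethylamino)methyl)carbonyl)amino.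

Within the data shown here, no measured pair isolates this change, so the data give no direct size for it. Among the measured compounds shown here, the only indirect guide is compound 1, which on a different core also carries a group on a saturated chain carbon bound to a carbonyl carbon and gives 230 nM, within the scatter of compound 2. In this assay, a step no larger than the scatter is expected, with no firm direction. The estimated step of a 1.1-fold lower number from compound 2 to compound 3 (0.05 log units; within the scatter) reflects that expectation. The expected value for compound 3 is 300 nM, with an estimated range of 110 nM to 800 nM.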

Compound 3, half-maximal inhibitory concentration: 110 nM
Compound 3: the middle estimate sits 2.7-fold (0.44 log units) above what was measured, and the stated range covers the measured number.
By their numbers in this assay, from the lowest: compound 3; then compounds 1 and 2 (each within the scatter of the next).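

The chain carbon bound to the carbonyl carbon in the acetamido group of compound 2 responds to substitution in this assay: dimethylamino in place of hydrogen gives a 3.1-fold lower number from compound 2 to compound 3 (0.49 log units; beyond the scatter) and this modest step lies beyond the scatter. This position therefore accepts a group of 3 heavy atoms, 1 of them nitrogen, without any loss in this read-out, and the change turns acetamido into (((dimethylamino)methyl)carbonyl)amino with a lower number as the outcome. No measurement at hand bears on what lies behind this step.

This single pair cannot show whether the lower number depends on the amine nitrogen or would follow from other groups at the same place, such as a primary amine, a carboxylic acid, or an ethyl group with no nitrogen at all. As far as these compounds go, how the two methyl groups on the nitrogen contribute and whether a longer chain between the carbonyl carbon and the dimethylamino group keeps the step also remain open on the shared core.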